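Flipping one ring stereocentre on a fluorocyclopropyl amide

The source may hold more compounds than are shown below. What is called first, only, known or untested is meant among the compounds shown, and "the series" means these compounds.

Measured compounds:
compound 1 `CC(=O)N1CC2CC(C1)N2`, 150 nM
compound 2 `CCC(=O)N1CC2CC(C1)N2`, 6 nM
compound 3 `O=C([C@H]1C[C@H]1F)N1CC2CC(C1)N2`, 1.1 nM

Compound 3 gives the lowest number of the three in an assay on SH-EP1 cells for displacement of a labelled ligand from Neuronal acetylcholine receptor; alpha4/beta2 (Homo sapiens), read by scintillation counting; a higher number here means a weaker inhibitor, a lower number a stronger inhibitor: the step of a 5.5-fold lower number from compound 2 to compound 3 (0.74 log units; beyond the scatter) is modest, the step of a 140-fold lower number from compound 1 to compound 3 (2.13 log units; beyond the scatter) large. Compound 4 `O=C([C@@H]1C[C@H]1F)N1CC2CC(C1)N2` differs from compound 3 only in stereochemistry: the two compounds have the same atoms and bonds; at least one stereo element is drawn with a configuration in one of them and without one in the other: 1 of 4 stereo elements differ; a stereocentre at a saturated ring carbon is drawn R in compound 3 and S in compound 4. Among the measured compounds shown here, no measured step involves a change of configuration; the steps of a 25-fold lower number from compound 1 to compound 2 (1.40 log units; beyond the scatter) and a 5.5-fold lower number from compound 2 to compound 3 (0.74 log units; beyond the scatter) concern the group on the carbonyl carbon, which stays the same here. Compound 4 is therefore expected to keep a low number, with the risk that the flipped centre costs some affinity, so a small rise a 2.3-fold higher number from compound 3 to compound 4 (0.36 log units; beyond the scatter) is estimated. For compound 4 in this assay the estimate is 2.5 nM, within 0.6 nM to 12 nM.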

Compound 4, inhibition constant: 1 nM
Compound 4: the middle estimate sits 2.5-fold (0.40 log units) above what was measured; measured number inside the range.
By their numbers in this assay, from the lowest: compounds 4 and 3 (each within the scatter of the next); then compound 2; then compound 1.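

In this assay, flipping the ring stereocentre leaves the number unchanged within the scatter, with a 1.1-fold lower number from compound 3 to compound 4 (0.04 log units; within the scatter). The 2-fluorocyclopropyl group keeps its full lead over the shorter groups in this form too, with a 6.0-fold lower number from compound 2 to compound 4 (0.78 log units; beyond the scatter) and a 150-fold lower number from compound 1 to compound 4 (2.18 log units; beyond the scatter). As a reading of configuration, this comparison carries one caveat: the fact that one of compounds 3 and 4 is drawn with a defined configuration and the other without, at the place where they differ

The compounds shown leave open whether a plain cyclopropyl group without the fluorine, or a 2-chlorocyclopropyl group, would give a similar number. They also leave open whether the other stereocentre on the fluorocyclopropyl ring tolerates flipping equally well.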